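Fluorine Pattern on the Benzyl Group and Cytotoxicity

The source may report more compounds than this note shows. Statements on the series, on what has been measured and on what is new or still open speak of the compounds shown alone.

Compound 1 `CCOC(=O)/C(O)=C/C(=O)c1cn(Cc2cccc(F)c2F)c2cccc(OC)c12` and compound 2 `CCOC(=O)/C(O)=C/C(=O)c1cn(Cc2ccc(F)cc2F)c2cccc(OC)c12` share a core and differ only in the fluorine pattern of the benzyl group. In an ADME assay on MT4 cells (Homo sapiens) for cytotoxicity, read by MTT assay (a higher number here means that more compound is tolerated, a lower number that less compound is tolerated), compound 1 gives 21100 nM, and compound 2 gives 65500 nM, the higher of the two numbers; the step of a 3.1-fold higher number from compound 1 to compound 2 (0.49 log units; beyond the scatter) is the only one so far. Compound 3 `CCOC(=O)/C(O)=C/C(=O)c1cn(Cc2c(F)ccc(F)c2F)c2cccc(OC)c12` carries the next change: 2,3,6-trifluorophenyl in place of 2,4-difluorophenyl on a saturated chain carbon bound to an aromatic nitrogen. The earlier step bears on it in kind, since it too rearranged fluorine on the same ring, but it points in no fixed direction for a third fluorine, so for compound 3 a step of modest size in either direction is expected, a 1.6-fold lower number from compound 2 to compound 3 (0.21 log units; within the scatter). Compound 3 is therefore expected to give about 40000 nM in this assay, within a range from 15000 nM to 110000 nM.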

Compound 3, half-maximal cytotoxic concentration: 40500 nM
For compound 3 the middle estimate is 1.0-fold (0.01 log units) below the measured one, within the range that was stated.
By their numbers in this assay, from the lowest: compounds 1, 3 and 2 (each within the scatter of the next, the first and the last beyond it).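

Moving to the 2,3,6-trifluorophenyl group on a saturated chain carbon bound to an aromatic nitrogen gives no step beyond the scatter in this assay (a 1.6-fold lower number from compound 2 to compound 3 (0.21 log units; within the scatter)), so this position accepts a third fluorine without a clear shift in the number. Going by these compounds alone, the single replacement of hydrogen by fluoro on an aromatic carbon also stays within the scatter (a 1.9-fold higher number from compound 1 to compound 3 (0.28 log units; within the scatter)), which leaves compound 3 unresolved from both of the earlier compounds, even though those two lie beyond the scatter of each other. Nothing measured on the cause accompanies these numbers.

It remains open whether an unsubstituted benzyl group, or a chlorine or methyl group in place of fluorine, would stay among these numbers. Equally open, on these data alone, is what a carboxylic acid in place of the ethyl ester would do.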